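Replacing Cyano with Acetamido on an Aromatic Carbon

The source may report more compounds than this note shows. Statements on the series, on what has been measured and on what is new or still open speak of the compounds shown alone.

Within the data shown here, in an ADME assay on L02 cells (Homo sapiens) for cytotoxicity, read by MTT assay, with a stated time of 24 h (on this read-out higher numbers stand for weaker inhibition and lower numbers for stronger inhibition), compound 1 `O=C1/C(=C/c2cccnc2)CN(S(=O)(=O)c2ccc([N+](=O)[O-])cc2)C/C1=C\c1ccccc1C(F)(F)F` gives 15700 nM and compound 2 `N#Cc1ccc(S(=O)(=O)N2C/C(=C\c3cccnc3)C(=O)/C(=C/c3ccccc3C(F)(F)F)C2)cc1` gives 13200 nM, so compound 2 stands within the scatter of its only measured neighbour. Compound 3 `CC(=O)Nc1ccc(S(=O)(=O)N2C/C(=C\c3cccnc3)C(=O)/C(=C/c3ccccc3C(F)(F)F)C2)cc1` differs from compound 2 at one place: acetamido in place of cyano on an aromatic carbon. In words, this is acetamido in place of cyano on an aromatic carbon. Among the measured compounds shown here, the only measured step at that carbon, a 1.2-fold lower number from compound 1 to compound 2 (0.08 log units; within the scatter), stayed within the scatter, although it involved a different pair of groups, so no change beyond the scatter is expected. The estimated step is a 1.1-fold higher number from compound 2 to compound 3 (0.06 log units; within the scatter). Compound 3 is expected at 15000 nM, with an estimated range of 7000 nM to 32000 nM.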

Compound 3, half-maximal inhibitory concentration: 15300 nM
Compound 3: middle estimate off by 1.0-fold (0.01 log units), on the low side; the measured number falls inside the stated range.
By their numbers in this assay, from the lowest: compounds 2, 3 and 1 (each within the scatter of the next).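

Acetamido is larger than cyano by heavy-atom count and brings a hydrogen-bond donor, yet in this assay the step stays within the scatter (a 1.2-fold higher number from compound 2 to compound 3 (0.06 log units; within the scatter)). The comparison with nitro also stays within the scatter (a 1.0-fold lower number from compound 1 to compound 3 (0.01 log units; within the scatter)). Across these three compounds, the aromatic carbon para to a large group has therefore held three different groups with no change beyond the scatter, and nothing measured here explains this.
As far as these compounds go, whether an amine or a carboxylic acid at this carbon would also stay within the scatter remains open. So does the effect of a longer chain on the acetamido group.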